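Adding a Nitro Group to Compound 1

A few compounds are considered here, and "the series" means these few. Any claim that something is new, unique, unknown or untested is made for them only; others in the source may bear on it.

Compound 1 `O=C(Cn1c(=O)oc2ccccc21)Nc1nc2ccc([N+](=O)[O-])cc2s1`: 12.4%
Compound 2 `O=C(Cn1c(=O)oc2cc([N+](=O)[O-])ccc21)NCc1cccs1`: 36.6%

In an ADME assay on RAW264.7 cells (Mus musculus) for cytotoxicity, read by MTT assay, with a stated time of 72 h, tested at 50 uM (on this read-out lower numbers stand for a weaker effect and higher numbers for a stronger effect at the one concentration tested), compound 1 gives 12.4%, the lower of the two measured numbers. Compound 2 gives 36.6%, a gap beyond the usual scatter. Compound 3 `O=C(Cn1c(=O)oc2cc([N+](=O)[O-])ccc21)Nc1nc2ccc([N+](=O)[O-])cc2s1` has not been measured. It differs from compound 1 by nitro in place of hydrogen on an aromatic carbon. Among the compounds with values here, no measured pair shows this change on its own, so its effect in this assay is unknown; a small rise, or none beyond the scatter, seems the most likely outcome. Compound 3 is expected to give 20%, between 5% and 40%. This estimate means an expected step of a number 7.6 percentage points higher from compound 1 to compound 3 (within the scatter).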

Compound 3, a percentage reported as inhibition, at one concentration (the size of the read-out at that concentration, not a potency): 14.8%
Compound 3: the middle estimate sits 5.2 percentage points above what was measured; the measured number falls inside the stated range.
By their numbers in this assay, from the lowest: compounds 1 and 3 (each within the scatter of the next); then compound 2.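

In this assay, nitro in place of hydrogen on this aromatic carbon gives a number 2.4 percentage points higher from compound 1 to compound 3 (within the scatter). Within the data shown here, this is the first direct look at the change: at this position, on the core of compound 1, adding nitro does not move the read-out past ordinary repeat variation. No available measurement offers an explanation for this result. On these data alone, whether an amine or a carboxylic acid on the same carbon would also leave the read-out unmoved remains open. A single step also cannot show whether nitro would behave this way on another core.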